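Chlorination of a purine-like core in two benzyl series

The source may hold more compounds than are shown below. What is called first, only, known or untested is meant among the compounds shown, and "the series" means these compounds.

Measured compounds:
- compound 1 `ClCc1ccccc1Cn1cnc2c(Cl)nc(Cl)nc21`: 4360 nM
- compound 2 `ClCc1ccccc1Cn1cnc2c(Cl)ncnc21`: 18200 nM
- compound 3 `ClCc1cccc(Cn2cnc3c(Cl)ncnc32)c1`: 51300 nM

All three were run in a functional assay on SK-MEL-2 cells (Homo sapiens) for cytotoxicity, read by sulforhodamine B assay, with a stated time of 48 h; a higher number here means a weaker inhibitor of growth, a lower number a stronger inhibitor of growth. Compound 1 and compound 2 share a core; the difference between them is chloro in place of hydrogen on an aromatic carbon and this change gave a 4.2-fold lower number from compound 2 to compound 1 (0.62 log units; beyond the scatter). Compound 3 is a rearranged form of compound 2 with the same atoms joined differently; how the two cores differ is not broken down here. Compound 3 gives the highest of the three numbers in this assay.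

Compound 4 `ClCc1cccc(Cn2cnc3c(Cl)nc(Cl)nc32)c1` is not yet measured. It differs from compound 3 by chloro in place of hydrogen on an aromatic carbon, the same change as that from compound 2 to compound 1, at a place described in the same words. For compound 4 the expected step is a 4.3-fold lower number from compound 3 to compound 4 (0.63 log units; beyond the scatter), resting on compound 3 at 51300 nM and on the earlier step of a 4.2-fold lower number from compound 2 to compound 1 (0.62 log units; beyond the scatter). Compound 4 is therefore estimated at 12000 nM, with a likely range from 5000 nM to 30000 nM.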

Compound 4, concentration for total growth inhibition: 4460 nM
Compound 4: the middle estimate sits 2.7-fold (0.43 log units) above what was measured, outside the stated range (below it).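

In this assay, chloro in place of hydrogen on an aromatic carbon gave a 12-fold lower number from compound 3 to compound 4 (1.06 log units; beyond the scatter), the same direction as on the other core. Going by these compounds alone, the direction of the change carries across these two cores, but its size does not: the same change on two cores in this assay, a 4.2-fold lower number (0.62 log units; beyond the scatter) from compound 2 to compound 1 and a 12-fold lower number (1.06 log units; beyond the scatter) from compound 3 to compound 4, 2.8-fold (0.44 log units) apart, beyond the scatter of two such steps With only two pairs, this does not show how the change would behave on a further core, and the data do not identify what sets the gap between the two steps.

The compounds shown carry only hydrogen or chloro at this place between two ring nitrogen atoms, leaving an amine or a methoxy group there open. Also open, on these data alone, is a hydroxymethyl group in place of the chloromethyl group on the benzyl ring.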